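This account rests on a few compounds, and the source may have more. Where it says the series, first, only, none or still open, it means among the compounds named here.

Working notes on the series.

Compound 1 `C[C@@H](O)[C@H]1C(=O)N2C(C(=O)OCOC(=O)C3CCCCC3)=C(S[C@@H]3CN[C@H](C(=O)Nc4cccc(C(=O)O)c4)C3)[C@H](C)[C@H]12` is the reference point. In a physicochemical assay for metabolic stability, read by LC-MS, in phosphate buffer, with a stated time of 3 h, at pH 7.4, tested at 50 uM (on this read-out higher numbers stand for a more stable compound and lower numbers for a less stable compound), compound 1 gives > 95%, which is a limit of the assay rather than a number. Compound 2 `CCOC(=O)C1=C(S[C@H]2C[C@@H](C(=O)Nc3cccc(C(=O)OCC)c3)N(Cc3oc(=O)oc3C)C2)[C@H](C)[C@@H]2[C@@H]([C@@H](C)O)C(=O)N12` shares the same read-out behaviour: in this assay compound 2 gives > 95%, again a limit and not a number. Where compound 1 stands can therefore be stated only as a position at the limit of > 95% in this assay, at which 2 of the 2 values shown sit, with no gradation between the two measured compounds; nothing in the numbers shown separates them.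

Compound 3 `C[C@@H](O)[C@H]1C(=O)N2C(C(=O)OCOC(=O)OC(C)(C)C)=C(S[C@@H]3CN[C@H](C(=O)Nc4cccc(C(=O)O)c4)C3)[C@H](C)[C@H]12` is the next point. Its change from compound 1 is tert-butoxy in place of cyclohexyl on a carbonyl carbon whose other neighbour is an oxygen next to a carbonyl group. Going by the values given here, no step between measured compounds is available, so the expectation rests on compound 1 sitting at the limit > 95% in this assay. The step from compound 1 to compound 3 is expected to be a number no higher from compound 1 to compound 3 (the limit leaves the size open), none beyond the scatter. Compound 3 is therefore estimated at 95% in this assay, within 85% to 99%, most likely reported again as a limit.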

Compound 3, percent of the compound remaining: > 95%
Compound 3: no number, only a limit (the forecaster's own chance of this, stated with the estimate: 70%); the middle value lies on the limit itself.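

In this assay, going by these compounds alone, compound 3 gives > 95% as a limit and not a number, so no step from compound 1 to compound 3 can be read. From the compounds shown here alone, whether compound 1, compound 2 and compound 3 differ at all in this assay stays open, as does whether tert-butoxy in place of cyclohexyl on a carbonyl carbon changes the read-out. The series so far stands at one position: the limit of > 95% in this assay, at which 3 of the 3 values shown sit.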